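Acid Chain to Hydroxypiperidine Amide on a Spiro Core

This account rests on a few compounds, and the source may have more. Where it says the series, first, only, none or still open, it means among the compounds named here.

Measured compounds:
- compound 1, `CCc1nn(CC)c(C2CCN(C(=O)CN3CN(c4ccccc4)C4(CCN(C(=O)c5ccc(C6CCCCC6)cc5)CC4)C3=O)CC2)c1C`: "not determined" (no result reported) in an assay on HEK293 cells for displacement of a labelled ligand from NPC1-like intracellular cholesterol transporter 1 (Homo sapiens); a lower number here means a stronger inhibitor, a higher number a weaker inhibitor
- compound 2, `CC(C)(C)c1ccc(C(=O)N2CCC3(CC2)C(=O)N(CC(=O)NCCC(=O)O)CN3c2ccccc2)cc1`: 11400 nM

Among the measured compounds shown here, compound 2 is the only compound with a number in this assay; compound 1 was tested but no value was recorded for it, so compound 2 stands alone and no comparison between measured compounds can be drawn. On its own, compound 2 gives 11400 nM in this assay, a weak inhibition.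

Compound 3, `CC(C)(C)c1ccc(C(=O)N2CCC3(CC2)C(=O)N(CC(=O)N2CCCC(O)C2)CN3c2ccccc2)cc1`, has not yet been measured. It differs from compound 2 in a single place: 3-hydroxypiperidin-1-yl in place of (2-carboxyethyl)amino on a carbonyl carbon. The rest of the shared core is unchanged.

For the measured compounds named here, with no measured step available, the size and direction of the change can only be expected, not inferred from data. Compound 3 is estimated to come in at 6000 nM, within a range of 1500 nM to 25000 nM. The step from compound 2 to compound 3 that this estimate means, a 1.9-fold lower number from compound 2 to compound 3 (0.28 log units; within the scatter), is expected to be modest, toward somewhat stronger inhibition but close to the usual scatter of the assay.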

Compound 3, half-maximal inhibitory concentration: 12200 nM
Estimate against measurement, compound 3: 2.0-fold (0.31 log units) below, within the range that was stated.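

In this assay, putting 3-hydroxypiperidin-1-yl in place of (2-carboxyethyl)amino on a carbonyl carbon gives a 1.1-fold higher number from compound 2 to compound 3 (0.03 log units; within the scatter), so the two compounds cannot be told apart. This first step at the position shows that an open chain ending in a carboxylic acid and a six-membered non-aromatic ring bearing a hydroxyl group read alike here, even though the exchange replaces the chain with a ring and removes the carboxylic acid. No measurement is at hand that would explain this result.

The compounds shown leave open whether any group on this carbonyl carbon can move the number beyond the scatter, for instance a piperidine without the hydroxyl group, a dimethylamino group or a longer chain ending in a carboxylic acid. They also leave open whether the 3-hydroxypiperidin-1-yl group would read the same with the cyclohexyl group of compound 1 in place of the tert-butyl group, since the entry for compound 1 holds no number.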